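The compounds below may be only part of what the source reports. "The series", "measured", "known", "first", "only" and "open" are said of these compounds alone.

Measured so far:
- compound 1, `CCCCCN(C)/N=N/c1nc[nH]c1C(N)=O`: 3.58
- compound 2, `C#CCN(C)/N=N/c1nc[nH]c1C(N)=O`: 3.61

In a functional assay on L1210 cells (Mus musculus) for antiproliferative activity (a higher number here means a more potent compound, by a factor of ten per unit of this negative logarithm, a lower number a less potent compound), compound 1 gives 3.58 and compound 2 gives 3.61. Of the two numbers, that of compound 2 is the higher, though only by a number 0.03 log units higher from compound 1 to compound 2 (within the scatter), a gap too small to mean anything. The two compounds share one core and differ only in the chain on the nitrogen.

Compound 3, `CN(Cc1ccccc1)/N=N/c1nc[nH]c1C(N)=O`, has not yet been measured in this assay. It differs from compound 2 at the same place: phenyl in place of ethynyl on a saturated chain carbon bound to an amine nitrogen. Within the data shown here, the only measured step that bears on this is the one at that same position, a number 0.03 log units higher from compound 1 to compound 2 (within the scatter), where trading one chain for another left the number essentially unchanged. Among the measured compounds shown here, that gives weak grounds, since a ring rather than a chain now enters, and no measured compound carries a ring there. With nothing pointing either way, no step beyond the scatter is expected, though the spread around that expectation must be wide.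

Compound 3 is therefore expected to give about 3.7, most likely between 3.2 and 4.3. The expected step is a number 0.09 log units higher from compound 2 to compound 3 (within the scatter).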

Compound 3, logarithm of the reciprocal of the active concentration, log(1/C): 3.43
For compound 3 the middle estimate is 0.27 log units above the measured one; low and high end bracket the measured number.
By their numbers in this assay, from the lowest: compounds 3, 1 and 2 (each within the scatter of the next).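

Compound 3 is the first of these compounds to carry a ring at this place, on a saturated chain carbon bound to an amine nitrogen, and in this assay swapping ethynyl, with its 2 heavy atoms and triple bond, for phenyl, with 6 heavy atoms in a six-membered aromatic ring, gives a number 0.18 log units lower from compound 2 to compound 3 (within the scatter). Setting phenyl in place of butyl gives a number 0.15 log units lower from compound 1 to compound 3 (within the scatter), so across compounds 1, 2 and 3 a saturated chain, a triple bond and an aromatic ring all give numbers within the scatter of one another, and neither the size of the group nor the presence of a ring produces a readable difference among these three. Nothing available explains why these numbers stay so close.

Going by these compounds, all three groups have no hydrogen-bond donors or acceptors and no net charge, so it remains open whether an amine or a carboxylic acid at this place would shift the number beyond the scatter. A much longer chain, or a phenyl ring bearing a hydroxyl group, is equally untested by the compounds shown here.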